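The compounds below may be only part of what the source reports. "The series", "measured", "known", "first", "only" and "open" are said of these compounds alone.

Among the compounds with values here, compound 2 `O=C(N[C@H]1CCC[C@H](NC(=O)c2ccccc2F)C1)c1cccc(Cl)c1` is one of two compounds measured in a functional assay on HEK293 cells for antagonist activity at metabotropic glutamate receptor 5 (Homo sapiens), read by FLIPR and calcium flux; on this read-out lower numbers stand for stronger inhibition and higher numbers for weaker inhibition. In this assay compound 2 gives 175 nM. Within the data shown here, its only measured companion is compound 1 `COc1ccc(C(=O)N[C@H]2CCC[C@H](NC(=O)c3cccc(Cl)c3)C2)cc1`, which carries a 4-methoxyphenyl on the same carbonyl carbon; in this assay compound 1 gives 266 nM. The step of a 1.5-fold lower number from compound 1 to compound 2 (0.18 log units; within the scatter) is the only one available, and it is too small to separate the two compounds, so compound 2 and compound 1 sit within the scatter of each other.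

The next compound, compound 3 `O=C(N[C@H]1CCC[C@H](NC(=O)c2cccc(Cl)c2)C1)c1ccc(F)cc1`, changes only where the fluorine sits on that ring: 4-fluorophenyl in place of 2-fluorophenyl on a carbonyl carbon. Among the measured compounds shown here, no measured step moves a fluorine around a ring, so the nearest guide is the step from compound 1 to compound 2, in which exchanging one benzoyl group for another, including a change from a ring substituted in the 4-position to one substituted in the 2-position, left the number within the scatter. On that basis a shift of a 1.3-fold higher number from compound 2 to compound 3 (0.10 log units; within the scatter) is expected, that is no change beyond the scatter in either direction. Compound 3 is therefore estimated at 220 nM, with a range from 80 nM to 650 nM.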

Compound 3, half-maximal inhibitory concentration: 194 nM
Compound 3: the middle estimate sits 1.1-fold (0.05 log units) above what was measured; measured number inside the range.
By their numbers in this assay, from the lowest: compounds 2, 3 and 1 (each within the scatter of the next).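

Within the data shown here, for the first time, the same substituent can be compared in two placements: in this assay, 4-fluorophenyl in place of 2-fluorophenyl on a carbonyl carbon gives a 1.1-fold higher number from compound 2 to compound 3 (0.04 log units; within the scatter) and so does not separate the two placements. Among these compounds, compound 3 also supplies a cleaner comparison than the earlier pair, since only one substituent on the ring differs: fluoro in place of methoxy on an aromatic carbon gives a 1.4-fold lower number from compound 1 to compound 3 (0.14 log units; within the scatter) and leaves these two compounds unresolved as well, so at this position neither change has yet produced a measurable difference in this read-out. No measured information is available to explain these numbers.

From the compounds shown here alone, all three compounds keep a phenyl ring with a small substituent on this carbonyl carbon, so it remains open whether a ring carrying an amine, a carboxylic acid or a longer chain such as butoxy, or a non-aromatic group such as cyclohexyl, would move the number beyond the scatter. The rest of the shared core is identical in all three compounds, so these comparisons say nothing about how changes there would behave.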